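A few compounds are considered here, and "the series" means these few. Any claim that something is new, unique, unknown or untested is made for them only; others in the source may bear on it.

Compound 2 `COc1ccc(C2CC2C(=O)NNC(=O)c2ccncc2)cc1` carries a methoxy group on the aromatic ring of the shared core. In a functional assay on PC-3 cells (Homo sapiens) for inhibition, read by MTT assay, with a stated time of 72 h (a higher number here means a weaker inhibitor, a lower number a stronger inhibitor), compound 2 reaches only the limit of the measurement, > 100000 nM. Its nearest measured neighbour, compound 1 `O=C(NNC(=O)C1CC1c1ccc(OCC(F)(F)F)cc1)c1ccncc1`, gives 44000 nM in this assay. Among the compounds with values here, the single measured step, an at least 2.2-fold higher number from compound 1 to compound 2 (0.35 log units; beyond the scatter), therefore runs toward weaker inhibition when trifluoromethyl is replaced by hydrogen, though its size rests on (the limit of > 100000 nM in this assay, at which 1 of the 2 values shown sits). Compound 3 `CC(C)=CCOc1ccc(C2CC2C(=O)NNC(=O)c2ccncc2)cc1` makes the change (2-methylprop-1-en-1-yl in place of hydrogen on a saturated chain carbon bound to an oxygen on an aromatic ring). Within the data shown here, no measured step covers this group; the only comparison available is that compound 1 carries a substituent on the same chain carbon where compound 2 carries hydrogen. An estimate for compound 3 thus leans on compound 1 and its value 44000 nM, with wide uncertainty. The expected change is an at least 2.0-fold lower number from compound 2 to compound 3 (0.30 log units; that floor lies within the scatter). Compound 3 is expected to give about 50000 nM, between 15000 nM and 200000 nM.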

Compound 3, half-maximal inhibitory concentration: > 100000 nM
Compound 3: no number, only a limit; the forecaster's own chance of this, stated with the estimate: 40%; middle value at least 2.0-fold (0.30 log units) from the limit.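

In this assay compound 3 gives > 100000 nM, a limit of the assay and not a number, so 2-methylprop-1-en-1-yl on a saturated chain carbon bound to an oxygen on an aromatic ring ends at the same limit as hydrogen. Within the data shown here, with 2-methylprop-1-en-1-yl in place of trifluoromethyl the result is an at least 2.2-fold higher number from compound 1 to compound 3 (0.35 log units; beyond the scatter), which runs toward weaker inhibition, as the change to hydrogen did, and leaves trifluoromethyl the only one of these three groups with a readable value. The step between the two limit values cannot be read, and the size of the other steps rests on that limit: the limit of > 100000 nM in this assay, at which 2 of the 3 values shown sit.

On these data alone, whether the two compounds at the limit differ at all stays open. So does how a longer chain, an amine or a carboxylic acid on this chain carbon would read in this assay.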